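This account rests on a few compounds, and the source may have more. Where it says the series, first, only, none or still open, it means among the compounds named here.

Three compounds have so far been measured in a functional assay on the whole organism (artery, strain albino) with Rattus norvegicus as the target, with a stated time of 15 min, at a dose of 10 mg/kg by the oral route; on this read-out lower numbers stand for less inhibition and higher numbers for more inhibition at the one dose given (going by the name of the read-out):

compound 1 `COc1ccc(C2N=C(SCc3ccc(Cl)cc3)NC(C)=C2C(=O)Nc2ccc(F)cc2)cc1OC`, 3.1%
compound 2 `COc1ccc(C2N=C(SCc3ccc(F)cc3)NC(C)=C2C(=O)Nc2ccc(F)cc2)cc1OC`, 3.6%
compound 3 `COc1ccc(C2N=C(SCc3ccc(Cl)cc3)NC(C)=C2C(=O)Nc2ccc(Br)cc2)cc1`, 3.1%

Compound 1 and compound 2 share one core and differ in a single place: fluoro in place of chloro on an aromatic carbon. In this assay the step is a number 0.5 percentage points higher from compound 1 to compound 2 (within the scatter), so the two numbers are treated as alike. Compound 3 rests on a different core; the difference between the two cores is not broken down here. In this assay compound 3 gives 3.1%, which sits level with compound 1 at the digits given, and all three numbers lie together within the scatter of the method, so none can be set apart from the others.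

Compound 4 `COc1ccc(C2N=C(SCc3ccc(F)cc3)NC(C)=C2C(=O)Nc2ccc(Br)cc2)cc1` has not yet been measured. It stands to compound 3 as compound 2 stands to compound 1: fluoro in place of chloro on an aromatic carbon. The place of the change reads the same in both pairs, so this is the same change. Resting on the step of a number 0.5 percentage points higher from compound 1 to compound 2 (within the scatter), which stayed within the scatter, a step of similar small size is expected here, a number 0.5 percentage points higher from compound 3 to compound 4 (within the scatter). Compound 4 is therefore estimated to give 3.6% in this assay, with a range from 0% to 12%.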

Compound 4, a percentage reported as inhibition, in the whole organism at one dose (the size of the read-out at that dose, not a potency): 3.6%
Compound 4: the middle estimate sits on the measured number at the digits printed; the measured number falls inside the stated range.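

In this assay, putting fluoro in place of chloro on the core of compound 3 gives a number 0.5 percentage points higher from compound 3 to compound 4 (within the scatter), and this step can be set beside the one seen earlier on the other core. The same swap, 4-chlorobenzyl to 4-fluorobenzyl on the sulfur, reads alike on the two cores: the same change on two cores in this assay, a number 0.5 percentage points higher (within the scatter) from compound 1 to compound 2 and a number 0.5 percentage points higher (within the scatter) from compound 3 to compound 4, 0 percentage points apart, within the scatter of two such steps. Within the data shown here, this does not show that the change has any real effect that carries over, since each step on its own cannot be told apart from repeat-to-repeat noise, so the match is between two small steps and says only that neither core gave a larger one, and it rests on just two cores, one dose and one read-out.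

The compounds shown leave open whether any group on this benzyl ring can lift the number clear of the scatter, for instance a nitrile, an amine or a carboxylic acid in place of the chloro or fluoro, or whether a longer chain in place of the benzyl group would do so. They also leave open whether the swap would still read the same on a compound with a much larger inhibition, where a small step would be easier to see.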